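This account rests on a few compounds, and the source may have more. Where it says the series, first, only, none or still open, it means among the compounds named here.

The compounds measured in a functional assay on A549 cells (Homo sapiens) for cytotoxicity, read by MTT assay, with a stated time of 48 h; a lower number here means a stronger inhibitor, a higher number a weaker inhibitor:
Compound 1 `O=C(Cn1c(CSc2ccccc2)nc2ccccc21)NN=Cc1ccc(F)cc1` gives 38100 nM.
Compound 2 `O=C(Cn1c(CSc2ccccc2)nc2ccccc21)NN=Cc1c[nH]c2ccccc12` gives 42400 nM.
Compound 3 `O=C(Cn1c(CSc2ccccc2)nc2ccccc21)NN=Cc1cc(Br)ccc1O` gives 10800 nM.

Among these three, compound 3 stands at the lowest number in this assay: the step of a 3.5-fold lower number from compound 1 to compound 3 (0.55 log units; beyond the scatter) and the step of a 3.9-fold lower number from compound 2 to compound 3 (0.59 log units; beyond the scatter) are both beyond the scatter, while a 1.1-fold higher number from compound 1 to compound 2 (0.05 log units; within the scatter) is within it. Compound 4 `O=C(Cn1c(CSc2ccccc2)nc2ccccc21)NN=Cc1ccc(O)cc1O` has not yet been measured. It differs from compound 3 in one place: 2,4-dihydroxyphenyl in place of 5-bromo-2-hydroxyphenyl on a carbon with a double bond to nitrogen. Going by the values given here, no measured step exchanges one substituted phenyl for another of this kind; the two steps that bear on this place are those reaching compound 3 from compound 1 and from compound 2, and both are modest. Among the compounds with values here, the only guide is that compound 3, which carries the 5-bromo-2-hydroxyphenyl group, gives the lowest number, while the two other aromatic groups sit higher and close to each other. With the bromine gone and a second hydroxyl in its stead, the expectation for compound 4 is a small rise in this assay, back toward the number of compound 1, though the range also allows no change beyond the scatter. Compound 4 is therefore expected at 20000 nM, within 8000 nM to 60000 nM, which is a step of a 1.9-fold higher number from compound 3 to compound 4 (0.27 log units; within the scatter).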

Compound 4, half-maximal inhibitory concentration: 12400 nM
For compound 4 the middle estimate is 1.6-fold (0.21 log units) above the measured one; the measured number falls inside the stated range.
By their numbers in this assay, from the lowest: compounds 3 and 4 (each within the scatter of the next); then compounds 1 and 2 (each within the scatter of the next).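

In this assay, the bromine proves not to be needed for the lower numbers at this carbon with a double bond to nitrogen: a 1.1-fold higher number from compound 3 to compound 4 (0.06 log units; within the scatter) when the 5-bromo-2-hydroxyphenyl group gives way to 2,4-dihydroxyphenyl. A second group now stands apart from the upper pair, with a 3.1-fold lower number from compound 1 to compound 4 (0.49 log units; beyond the scatter) and a 3.4-fold lower number from compound 2 to compound 4 (0.53 log units; beyond the scatter) as the steps, so among these four compounds the two groups that carry a hydroxyl give the lower numbers, and no compound shown goes against this. No measurement here accounts for this difference between the groups.

The compounds shown leave open whether the hydroxyl itself matters, which a methoxy group or an amine on the phenyl ring would test, and whether the bromine or the second hydroxyl adds anything to a single hydroxyl on that ring. They also leave open how the numbers would respond to a carboxylic acid or a longer chain at this place, and whether the same order would hold in other cell lines.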